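The source may report more compounds than this note shows. Statements on the series, on what has been measured and on what is new or still open speak of the compounds shown alone.

Within the data shown here, compound 3 `CC1=NC(C)=C([N+](=O)[O-])C(c2cccnc2)/C1=C(\O)OC1CCCC1` is one of three compounds measured in a functional assay (cardiac atrium) for agonist activity, with Cavia porcellus as the target (a lower number here means that less compound is needed, a higher number that more compound is needed for the effect), where compound 3 gives 3280 nM. That places compound 3 second highest of the three numbers. Its nearest neighbour is compound 2 `CC1=NC(C)=C([N+](=O)[O-])C(c2ccncc2)/C1=C(\O)OC(C)(C)C`, which in this assay gives 2820 nM, a value within the scatter of that of compound 3. Among the measured compounds shown here, the furthest is compound 1 `CC1=NC(C)=C([N+](=O)[O-])C(c2ccccn2)/C1=C(\O)OC1CCCC1`, which in this assay gives 19800 nM; the single step that links them, a 6.0-fold lower number from compound 1 to compound 3 (0.78 log units; beyond the scatter), is the only one-change step among the measured compounds.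

The next compound, compound 4 `CC1=NC(C)=C([N+](=O)[O-])C(c2ccncc2)/C1=C(\O)OC1CCCC1`, differs from compound 3 by the change (pyridin-4-yl in place of pyridin-3-yl on a saturated ring carbon). For the measured compounds named here, no measured step covers this exact exchange. Going by the values given here, the only step on this carbon, a 6.0-fold lower number from compound 1 to compound 3 (0.78 log units; beyond the scatter), concerns a different pair of rings, so it gives the size that such an exchange can reach but not its direction here. Compound 2 already carries pyridin-4-yl, though it differs from compound 3 in another part of the molecule, and its value sits within the scatter of compound 3. On that basis a step no larger than the scatter is expected in this assay, in either direction, and the expected step from compound 3 to compound 4 is a 1.3-fold lower number from compound 3 to compound 4 (0.10 log units; within the scatter). Compound 4 is therefore estimated at 2600 nM, within a range from 900 nM to 7500 nM.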

Compound 4, half-maximal effective concentration: 4250 nM
For compound 4 the middle estimate is 1.6-fold (0.21 log units) below the measured one, and the stated range covers the measured number.
By their numbers in this assay, from the lowest: compounds 2, 3 and 4 (each within the scatter of the next); then compound 1.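

In this assay, the result shows that pyridin-3-yl and pyridin-4-yl on this saturated ring carbon cannot be told apart when cyclopentyl sits on the oxygen: the measured step is a 1.3-fold higher number from compound 3 to compound 4 (0.11 log units; within the scatter) and so gives no order between them. Pyridin-2-yl now stands apart from both of these rings, since the step to pyridin-4-yl, a 4.7-fold lower number from compound 1 to compound 4 (0.67 log units; beyond the scatter), joins the earlier 6.0-fold lower number from compound 1 to compound 3 (0.78 log units; beyond the scatter) and both lie beyond the scatter, so among these three cyclopentyl compounds only compound 1 differs clearly. Among these compounds, the result also gives the first one-change reading at the group on the oxygen, where cyclopentyl in place of tert-butyl with pyridin-4-yl held fixed gives a 1.5-fold higher number from compound 2 to compound 4 (0.18 log units; within the scatter) and thus no separation between the two groups.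

Nothing available here accounts for the separate standing of the pyridin-2-yl ring. Going by these compounds, it remains open whether a phenyl ring on the saturated ring carbon, an amine on the pyridine ring or a longer chain on the oxygen would move the number, and whether pyridin-2-yl stands apart when tert-butyl sits on the oxygen.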